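From a cyclopropyl amide to a fluorophenyl amide

A few compounds are considered here, and "the series" means these few. Any claim that something is new, unique, unknown or untested is made for them only; others in the source may bear on it.

Of the compounds shown here, three sharing one core have been measured in a physicochemical assay for solubility, read by HPLC; a lower number here means a less soluble compound, a higher number a more soluble compound. Compound 1 `CC1COC2(CCN(c3nc(=O)c4cc(C(F)(F)F)cc([N+](=O)[O-])c4s3)CC2)O1` gives 0.94 ug/mL. Compound 2 `O=C(c1ccccc1Cl)N1CCN(c2nc(=O)c3cc(C(F)(F)F)cc([N+](=O)[O-])c3s2)CC1` gives 8.18 ug/mL. Compound 3 `O=C(C1CC1)N1CCN(c2nc(=O)c3cc(C(F)(F)F)cc([N+](=O)[O-])c3s2)CC1` gives 52.9 ug/mL, the highest of the three numbers; its nearest neighbour is compound 2, and compound 1 lies furthest from it. Going by the values given here, the one step measured between compounds that differ in a single place is a 6.5-fold higher number from compound 2 to compound 3 (0.81 log units; beyond the scatter).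

Compound 4 `O=C(c1ccc(F)cc1)N1CCN(c2nc(=O)c3cc(C(F)(F)F)cc([N+](=O)[O-])c3s2)CC1` has not yet been measured in this assay. It differs from compound 3 as follows: 4-fluorophenyl in place of cyclopropyl on a carbonyl carbon. This change is close to the reverse of the step from compound 2 to compound 3, where a cyclopropyl took the place of a 2-chlorophenyl on the same carbonyl carbon. In compound 4 a 4-fluorophenyl takes the place of the cyclopropyl, so the movement is expected to run the other way, from compound 3 downward, with a size near that earlier step, though the two phenyl groups carry different halogens and the match is not exact. The expected step is a 5.3-fold lower number from compound 3 to compound 4 (0.72 log units; beyond the scatter). Compound 4 is therefore estimated at 10 ug/mL, within a range from 3 ug/mL to 30 ug/mL.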

Compound 4, solubility: 1.69 ug/mL
For compound 4 the middle estimate is 5.9-fold (0.77 log units) above the measured one, outside the stated range (below it).
By their numbers in this assay, from the lowest: compounds 1 and 4 (each within the scatter of the next); then compound 2; then compound 3.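

In this assay, going by these compounds alone, this carbonyl carbon proves more sensitive than the earlier compounds suggested: replacing cyclopropyl with 4-fluorophenyl gives a 31-fold lower number from compound 3 to compound 4 (1.50 log units; beyond the scatter), a larger step than the one seen earlier, a 6.5-fold higher number from compound 2 to compound 3 (0.81 log units; beyond the scatter). Among the three amides, the cyclopropyl group gives the highest number, but the two halogen-bearing phenyl groups are not interchangeable, as there is a 4.8-fold lower number from compound 2 to compound 4 (0.68 log units; beyond the scatter); this swap changes the halogen and its place on the ring together, so their separate contributions cannot be told apart. No measurement shown here explains why any of these steps has the size it does.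

A plain phenyl, 4-chlorophenyl or 2-fluorophenyl group on the same carbonyl carbon would help separate the identity of the halogen from its place on the ring. Within the data shown here, it also remains open whether a longer alkyl chain, or a phenyl ring carrying an amine or a carboxylic acid, would give a number near the one for compound 3, at 52.9 ug/mL.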